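A Methyl Group Added to Compound 3

The compounds below may be only part of what the source reports. "The series", "measured", "known", "first", "only" and "open" are said of these compounds alone.

Values measured in a physicochemical assay for lipophilicity, read by HPLC, in phosphate buffer, measured as octanol-water partition, with a stated time of 1 h, at pH 7.4 (a lower number here means a more polar compound, a higher number a more lipophilic compound), are these:
Compound 1 `COCC1=C[C@@](C)(c2cc(NC(=O)c3ccc(C#N)cn3)ccc2F)N=C(N)O1`: 2
Compound 2 `CC1=C[C@@](C)(c2cc(NC(=O)c3ccc(C#N)cn3)ccc2F)N=C(N)O1`: 2.2
Compound 3 `C[C@@]1(c2cc(NC(=O)c3ccc(C#N)cn3)ccc2F)C=COC(N)=N1`: 2

Compound 3 sits within the scatter of both other compounds. One measured step gives no change at the digits printed from compound 1 to compound 3 (within the scatter) and the other gives a number 0.20 log units lower from compound 2 to compound 3 (within the scatter) on the same scale. Compound 4 `CC1=COC(N)=N[C@]1(C)c1cc(NC(=O)c2ccc(C#N)cn2)ccc1F` departs from compound 3 by a single change, methyl in place of hydrogen on a double-bonded ring carbon and nothing else. Read backwards, compound 2 offers the closest precedent, with a number 0.20 log units lower from compound 2 to compound 3 (within the scatter) for hydrogen in place of methyl on a double-bonded ring carbon. A small move toward a higher number is therefore expected, no larger than the scatter, and the estimated step is a number 0.20 log units higher from compound 3 to compound 4 (within the scatter) for this change. Compound 4 is expected at 2.2 within a range from 1.9 to 2.5 on these grounds.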

Compound 4, distribution coefficient: 1.5
Compound 4: the middle estimate sits 0.70 log units above what was measured, and the stated range ends above it.
By their numbers in this assay, from the lowest: compound 4; then compounds 1, 3 and 2 (each within the scatter of the next).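

In this assay, methyl in place of hydrogen on this double-bonded ring carbon gives a number 0.50 log units lower from compound 3 to compound 4 (beyond the scatter), so at this position the change moves the number clearly, and toward the polar end. The methyl on the double-bonded ring carbon of compound 2 stays within the scatter of compound 3, while the exchange of the whole group gives a number 0.70 log units lower from compound 2 to compound 4 (beyond the scatter), so the same group does not behave alike at the two carbons. Nothing measured here explains the difference.

Going by these compounds, whether an ethyl or a hydroxymethyl group on this carbon would extend the step or reverse it stays open, as does whether a methyl on both double-bonded ring carbons would add the two effects.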